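Replacing fluoro with phenyl on a shared core

The compounds below may be only part of what the source reports. "The series", "measured", "known", "first", "only" and "open" are said of these compounds alone.

Among the measured compounds shown here, compound 3 `COc1ccc(C(=O)/C=C/c2ccc(F)cc2)c2c1C=CC(C)(C)O2` is one of three compounds measured in a functional assay on SW-620 cells (Homo sapiens) for antiproliferative activity, read by MTT assay, with a stated time of 24 h; on this read-out lower numbers stand for stronger inhibition and higher numbers for weaker inhibition. In this assay compound 3 gives > 10000 nM, which is a limit of the assay rather than a number. Compound 1 `COc1cccc(/C=C/C(=O)c2ccc(OC)c3c2OC(C)(C)C=C3)c1` likewise gives only a limit, > 10000 nM. Compound 2 `COc1cc(OC)c(OC)cc1/C=C/C(=O)c1ccc(OC)c2c1OC(C)(C)C=C2` also gives a limit, > 10000 nM. Because all three values sit at the limit (the limit of > 10000 nM in this assay, at which 3 of the 3 values shown sit), the step from compound 1 to compound 3, a step that the two limits leave unreadable from compound 1 to compound 3, cannot be read in size. Compound 4 `COc1ccc(C(=O)/C=C/c2ccc(-c3ccccc3)cc2)c2c1C=CC(C)(C)O2` differs from compound 3 by phenyl in place of fluoro on an aromatic carbon. For the measured compounds named here, no measured step touches this change, so the expectation rests on compound 3 standing at its limit of > 10000 nM. Compound 4 is estimated at 12000 nM, ranging from 3000 nM to 50000 nM. The step from compound 3 to compound 4 is expected to be a step that the limit leaves unreadable from compound 3 to compound 4.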

Compound 4, half-maximal inhibitory concentration: > 10000 nM
Compound 4: no number, only a limit (the forecaster's own chance of this, stated with the estimate: 70%); the middle value does not contradict the limit.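

In this assay compound 4 gives > 10000 nM, a limit and not a number, so its step from compound 3 cannot be read in size: the limit of > 10000 nM in this assay, at which 4 of the 4 values shown sit.

The compounds shown leave open whether any change on the shared core would yield a readable value.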